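Exposure of N-alkyl aminopyrimidines after oral dosing in rat

The source may report more compounds than this note shows. Statements on the series, on what has been measured and on what is new or still open speak of the compounds shown alone.

Measured compounds:
- compound 1 `Cc1nc(NC(C)(C)C)nc(N[C@@H]2C[C@H](CO)[C@@H](O)[C@H]2O)c1-c1nc2ccccc2s1`: 2220 ng.h/mL
- compound 2 `CCOCCNc1nc(C)c(-c2nc3ccccc3s2)c(N[C@@H]2C[C@H](CO)[C@@H](O)[C@H]2O)n1`: 1100 ng.h/mL
- compound 3 `Cc1nc(NCc2cccs2)nc(N[C@@H]2C[C@H](CO)[C@@H](O)[C@H]2O)c1-c1nc2ccccc2s1`: 242 ng.h/mL

In an ADME assay on the whole organism (plasma) for pharmacokinetics, with Rattus norvegicus as the target, with a stated time of 6 h, at a dose of 10 mg/kg by the oral route (a lower number here means less compound in the circulation, a higher number more compound in the circulation at the dose given), compound 1 stands highest of the three numbers. Compound 2 sits closest, and the step of a 2.0-fold lower number from compound 1 to compound 2 (0.30 log units; within the scatter) is within the scatter. Compound 3 lies furthest away: the step of a 9.2-fold lower number from compound 1 to compound 3 (0.96 log units; beyond the scatter) is a modest but real drop, and likewise a 4.5-fold lower number from compound 2 to compound 3 (0.66 log units; beyond the scatter).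

Compound 4 `Cc1nc(NCc2ccncc2)nc(N[C@@H]2C[C@H](CO)[C@@H](O)[C@H]2O)c1-c1nc2ccccc2s1` is not yet measured in this assay. It differs from compound 1 as follows: (pyridin-4-yl)methyl in place of tert-butyl on a nitrogen on an aromatic ring. The most closely related step seen so far is a 9.2-fold lower number from compound 1 to compound 3 (0.96 log units; beyond the scatter), where another arylmethyl group replaced tert-butyl on the same nitrogen on an aromatic ring and the number fell beyond the scatter. The step of a 2.0-fold lower number from compound 1 to compound 2 (0.30 log units; within the scatter) shows that not every replacement of tert-butyl at this position moves the number, but the arylmethyl case did. A drop of comparable size is therefore expected for compound 4, giving an estimated 5.6-fold lower number from compound 1 to compound 4 (0.74 log units; beyond the scatter). Compound 4 is expected at 400 ng.h/mL, with a range from 130 ng.h/mL to 1200 ng.h/mL.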

Compound 4, area under the concentration-time curve: 47.9 ng.h/mL
Beside the measured number, compound 4's estimate is 8.4-fold (0.92 log units) above it; the whole stated range lies above it.
By their numbers in this assay, from the lowest: compound 4; then compound 3; then compounds 2 and 1 (each within the scatter of the next).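

Arylmethyl groups on this nitrogen are not interchangeable: with the saturated chain carbon kept, pyridin-4-yl in place of thiophen-2-yl still gives a 5.1-fold lower number from compound 3 to compound 4 (0.70 log units; beyond the scatter), so the identity of the ring alone moves the number beyond the scatter. Against the two compounds without a ring on this chain the gap widens further, with a 46-fold lower number from compound 1 to compound 4 (1.67 log units; beyond the scatter) and a 23-fold lower number from compound 2 to compound 4 (1.36 log units; beyond the scatter), the first being the largest step seen so far at this position. Nothing available explains why the pyridin-4-yl group lowers the number this far.

As far as these compounds go, it remains open how phenyl or pyridin-3-yl on the same saturated carbon would stand against thiophen-2-yl and pyridin-4-yl, and so whether the ring nitrogen or its placement tracks with the fall. An oral exposure number alone also cannot separate uptake from clearance for any of these compounds.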